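From 2-chlorophenyl to 4-hydroxyphenyl

This account rests on a few compounds, and the source may have more. Where it says the series, first, only, none or still open, it means among the compounds named here.

In a functional assay on K562 cells (Homo sapiens) for antiproliferative activity, read by MTT assay, with a stated time of 24 h (a lower number here means a stronger inhibitor, a higher number a weaker inhibitor), compound 1 `COc1cccc(/C=C/C(=O)c2ccc(OC)c3c2OC(C)(C)C=C3)c1` gives > 10000 nM, which is a limit and not a number. Compound 2 `COc1ccc(C(=O)/C=C/c2cccc(F)c2)c2c1C=CC(C)(C)O2` gives > 10000 nM, also a limit. Compound 3 `COc1ccc(C(=O)/C=C/c2ccccc2Cl)c2c1C=CC(C)(C)O2` gives > 10000 nM, again only a limit.

Compound 4 `COc1ccc(C(=O)/C=C/c2ccc(O)cc2)c2c1C=CC(C)(C)O2` has 4-hydroxyphenyl in place of the 2-chlorophenyl of compound 3, on a double-bonded chain carbon bound to a double-bonded chain carbon: 4-hydroxyphenyl in place of 2-chlorophenyl on a double-bonded chain carbon bound to a double-bonded chain carbon.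

Two measured changes touch this same place. One is a step that the two limits leave unreadable from compound 1 to compound 3, and the other is a step that the two limits leave unreadable from compound 2 to compound 3. Neither gives a size to carry over, so no direction can be favoured with confidence.

The expected change is a step that the limit leaves unreadable from compound 3 to compound 4, and this is only a rough estimate. For compound 4 the estimated value is 15000 nM, within an expected range from 4000 nM to 50000 nM.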

Compound 4, half-maximal inhibitory concentration: > 10000 nM
Compound 4 gave a limit, no number; the forecaster's own chance of this, stated with the estimate: 65%; the middle value does not contradict the limit.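

Compound 4 gives only a limit, as do compounds 1, 2 and 3, so no step among these compounds can be read: the limit of > 10000 nM in this assay, at which 4 of the 4 values shown sit.

The compounds shown leave open whether any aromatic group at this place gives a measurable value.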